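This account rests on a few compounds, and the source may have more. Where it says the series, first, only, none or still open, it means among the compounds named here.

Measured compounds:
- Compound 1, `Cc1cc(C(=O)O)nn1Cc1cc(Br)ccc1OCc1ccc(Cl)cc1Cl`, gives 0.49 nM in a functional assay on CHO-K1 cells for antagonist activity at prostaglandin E2 receptor EP1 subtype (Homo sapiens), read by FLIPR; a lower number here means a stronger inhibitor, a higher number a weaker inhibitor.
- Compound 2, `Cc1cc(C(=O)O)nn1Cc1cc(Br)ccc1OCc1cccc(Cl)c1`, gives 427 nM in this assay.

Among the measured compounds shown here, compound 2 stands at the higher of the two numbers, so it is the weaker inhibitor of the pair, and its only neighbour is compound 1, reached through the step of an 870-fold higher number from compound 1 to compound 2 (2.94 log units; beyond the scatter). Compound 3, `Cc1cccc(COc2ccc(Br)cc2Cn2nc(C(=O)O)cc2C)c1`, is still to be measured in this assay. It differs from compound 2 by methyl in place of chloro on an aromatic carbon of the six-membered aromatic ring of carbon only, meta to a large group; the whole side group reads 3-methylbenzyl instead of 3-chlorobenzyl. For the measured compounds named here, the only measured step, an 870-fold higher number from compound 1 to compound 2 (2.94 log units; beyond the scatter), concerns a different change on that same side group, so no measured pair shows what swapping chloro for methyl does here. With nothing pointing either way, the number is expected to stay roughly where compound 2 has it, and the step of a 1.2-fold higher number from compound 2 to compound 3 (0.07 log units; within the scatter) is expected to remain within the scatter. Compound 3 is therefore estimated at 500 nM, with a range from 150 nM to 1700 nM.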

Compound 3, inhibition constant: 525 nM
Estimate against measurement, compound 3: 1.1-fold (0.02 log units) below; the measured number falls inside the stated range.
By their numbers in this assay, from the lowest: compound 1; then compounds 2 and 3 (each within the scatter of the next).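

At this aromatic carbon, methyl in place of chloro gives a 1.2-fold higher number from compound 2 to compound 3 (0.09 log units; within the scatter) in this assay, so this measurement does not tell these two groups apart, though each has one heavy atom and they differ in element. The wide gap to compound 1 also holds with the new group, as a 1100-fold higher number from compound 1 to compound 3 (3.03 log units; beyond the scatter) shows, so among the compounds shown, the weak reading of the 3-substituted side group is not limited to chloro. Nothing available explains why chloro and methyl read alike here.

Other groups at this carbon, such as methoxy, trifluoromethyl or an amine, might or might not read the same way as chloro and methyl, so two matching groups set no rule for the position. Going from the 2,4-dichlorophenyl group to either 3-substituted group changes both the number and the places of the ring substituents at once, so it also remains open whether 2-chlorophenyl or 4-chlorophenyl alone would recover much of the strength of compound 1.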